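Phenoxy to benzyloxy: working notes on compound 4

A few compounds are considered here, and "the series" means these few. Any claim that something is new, unique, unknown or untested is made for them only; others in the source may bear on it.

Compound 1 `O=C(O)c1ccc(C(=O)c2ccc(Oc3ccccc3)cc2)cc1` gives 33% in an assay for displacement of a labelled ligand from 3-oxo-5-alpha-steroid 4-dehydrogenase 2 (Rattus norvegicus), at pH 5.5, tested at 10 uM (on this read-out lower numbers stand for less inhibition and higher numbers for more inhibition at the one concentration tested (going by the name of the read-out)), the second highest of the three numbers in hand. Compound 3 `O=C(O)c1ccc(C(=O)c2ccc(OCc3cc(C(F)(F)F)ccc3C(F)(F)F)cc2)cc1` gives 29%, a number within the scatter of compound 1, and compound 2 `O=C(O)c1ccc(C(=O)c2cccc(OCc3ccccc3)c2)cc1` gives 55%, a number higher than compound 1 and beyond the scatter. Compound 4 `O=C(O)c1ccc(C(=O)c2ccc(OCc3ccccc3)cc2)cc1` is not yet measured; it differs from compound 1 by benzyl in place of phenyl on an oxygen on an aromatic ring, phenoxy to benzyloxy. For the measured compounds named here, no measured pair shows this one change on its own, so the size of the step rests on the three numbers above. The expected step is a number 9 percentage points higher from compound 1 to compound 4 (within the scatter), a small rise that may only just clear the scatter. Compound 4 is estimated at 42%, with a range from 22% to 62%.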

Compound 4, a percentage reported as inhibition, at one concentration (the size of the read-out at that concentration, not a potency): 45%
Compound 4: the middle estimate sits 3 percentage points below what was measured, and the stated range covers the measured number.
By their numbers in this assay, from the lowest: compounds 3 and 1 (each within the scatter of the next); then compounds 4 and 2 (each within the scatter of the next).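

Benzyl in place of phenyl on an oxygen on an aromatic ring is now seen as a single change in this assay, and the step is a number 12 percentage points higher from compound 1 to compound 4 (beyond the scatter), a modest rise on the shared core. This rests on one pair at one concentration, so it gives a direction for this change at this position and no more. Nothing in hand accounts for the rise. Open, as far as these compounds go, is how a phenethyl group in place of benzyl on this oxygen would read, and likewise an amine in place of the oxygen itself.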